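Trading an isopentyl ester for a methyl thioester

A few compounds are considered here, and "the series" means these few. Any claim that something is new, unique, unknown or untested is made for them only; others in the source may bear on it.

Compound 1, `COC(C)(C)CCCC(C)C/C=C/C(C)=C/C(=O)OCCC(C)C`, stands highest in a physicochemical assay for lipophilicity (a lower number here means a more polar compound, a higher number a more lipophilic compound), giving 7.03. Compound 2, `C=C(C)CCCC(C)C/C=C/C(C)=C/C(=O)OCC`, gives 6.19, and compound 3, `CCOC(=O)/C=C(C)/C=C/CC(C)CCC(=O)C(C)C`, gives 4.3. Within the data shown here, the only step between compounds differing in one place is a number 1.89 log units lower from compound 2 to compound 3 (beyond the scatter), a change on the saturated chain far from the carbonyl end, so it does not bear directly on the change considered here. Compound 4, `COC(C)(C)CCCC(C)C/C=C/C(C)=C/C(=O)SC`, differs from compound 1 by methylsulfanyl in place of isopentyloxy on a carbonyl carbon. Among the measured compounds shown here, no measured step touches this carbonyl end, so the expectation rests on the change alone; a lowering beyond the scatter is expected, with the step of a number 1.43 log units lower from compound 1 to compound 4 (beyond the scatter). Compound 4 is therefore estimated at 5.6, ranging from 4.9 to 6.3.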

Compound 4, partition coefficient: 6.24
The estimate for compound 4 lay 0.64 log units below the measured number; the range from low to high includes it.
By their numbers in this assay, from the lowest: compound 3; then compounds 2 and 4 (each within the scatter of the next); then compound 1.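

In this assay, the carbonyl end of the chain gives its first readable step: methylsulfanyl in place of isopentyloxy on a carbonyl carbon gives a number 0.79 log units lower from compound 1 to compound 4 (beyond the scatter). This single step changes both the sulfur or oxygen atom on the carbonyl carbon and the size of the group, so the two contributions cannot be separated. Nothing available explains the size of the step. Methoxy and isopentylsulfanyl would each vary one of these features alone. On these data alone, whether the step carries over to the cores of compound 2 or compound 3 remains open.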